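This account rests on a few compounds, and the source may have more. Where it says the series, first, only, none or still open, it means among the compounds named here.

Measured in a functional assay on HCT-116 cells (Homo sapiens) for antiproliferative activity, read by MTT assay, with a stated time of 48 h; on this read-out higher numbers stand for weaker inhibition and lower numbers for stronger inhibition:
Compound 1 `COc1ccc(-c2c(Nc3cc(OC)c(OC)c(OC)c3)c3ccccc3oc2=O)cc1`: 63500 nM
Compound 2 `COc1ccc(-c2c(Nc3ccc(F)cc3)c3ccccc3oc2=O)cc1`: 39400 nM

In this assay, compound 2 gives 39400 nM and compound 1 gives 63500 nM. Within the data shown here, these two numbers lie within the usual scatter of each other, so they cannot be ranked, and compound 2 stands level with the only other measured compound. Among the measured compounds shown here, no pair of measured compounds differing in one place is available, so the data give no direct measure of how far a single change moves this read-out.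

Compound 3 `COc1ccc(-c2c(Nc3ccc(C)c(O)c3)c3ccccc3oc2=O)cc1` comes from compound 2 through one change: 3-hydroxy-4-methylphenyl in place of 4-fluorophenyl on a nitrogen on an aromatic ring. In words, it has 3-hydroxy-4-methylphenyl in place of 4-fluorophenyl on a nitrogen on an aromatic ring. Because compound 1 gives 63500 nM and compound 2 gives 39400 nM, only a modest shift is expected in this assay, leaning slightly toward stronger inhibition. The expected step of a 1.4-fold lower number from compound 2 to compound 3 (0.15 log units; within the scatter) may well not clear the scatter. For compound 3 the estimate is 28000 nM, with an expected range of 9000 nM to 70000 nM.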

Compound 3, half-maximal inhibitory concentration: 12300 nM
Beside the measured number, compound 3's estimate is 2.3-fold (0.36 log units) above it; measured number inside the range.
By their numbers in this assay, from the lowest: compound 3; then compounds 2 and 1 (each within the scatter of the next).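

In this assay, among these compounds, the exchange of 4-fluorophenyl for 3-hydroxy-4-methylphenyl on the nitrogen gives a 3.2-fold lower number from compound 2 to compound 3 (0.51 log units; beyond the scatter), the first single-place comparison in this set, and it shows that the aryl group at this position can move the read-out beyond the scatter, here toward stronger inhibition. The exchange removes the fluorine and brings in a hydroxy group and a methyl group together, with the entering group counting 1 hydrogen-bond donor and 1 hydrogen-bond acceptor where the leaving group counts none. No measurement available here explains the step or ties it to any one of these differences.

The compounds shown leave open whether the hydroxy group, the methyl group or the loss of the fluorine carries the step, since all three differences arrive in a single exchange. A phenyl ring bearing only the hydroxy group or only the methyl group on this nitrogen would separate them, and a methoxy or amino group in place of the hydroxy group would test how specific the step is to that group.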